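Isobutoxy to propoxy: from compound 3 to compound 4

The source may hold more compounds than are shown below. What is called first, only, known or untested is meant among the compounds shown, and "the series" means these compounds.

Measured in a functional assay on PC-12 cells (Rattus norvegicus) for inhibition, read by sulforhodamine B assay; a lower number here means a stronger inhibitor, a higher number a weaker inhibitor:
- compound 1 `O=C1NC(=O)C(Cc2ccc(OCC3CCCC3)cc2)S1`: 25000 nM
- compound 2 `O=C1NC(=O)C(Cc2ccc(OCC3CCC3)cc2)S1`: > 100000 nM (a limit of the assay, not a number)
- compound 3 `CC(C)COc1ccc(CC2SC(=O)NC2=O)cc1`: 25000 nM

Compound 3 stands level with compound 1, with no change at the digits printed from compound 1 to compound 3 (within the scatter), and the other comparison gives an at least 4.0-fold lower number from compound 2 to compound 3 (0.60 log units; beyond the scatter). Compound 4 `CCCOc1ccc(CC2SC(=O)NC2=O)cc1` carries hydrogen in place of methyl on a saturated chain carbon bound to two saturated chain carbons, which reads as isobutoxy to propoxy. Within the data shown here, no measured step makes this exact change. The nearest evidence is the replacement of the cyclopentyl group, which gave no change at the digits printed from compound 1 to compound 3 (within the scatter) with isopropyl but an at least 4.0-fold higher number from compound 1 to compound 2 (0.60 log units; beyond the scatter) with cyclobutyl. Changes here can therefore be silent or sizeable, so the range stays wide, with no step beyond the scatter expected in this assay. The expected step is a 1.2-fold higher number from compound 3 to compound 4 (0.08 log units; within the scatter). Compound 4 is estimated at 30000 nM, within an expected range of 12000 nM to 90000 nM.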

Compound 4, half-maximal inhibitory concentration in the PC-12 assay: 45000 nM
Compound 4: the middle estimate sits 1.5-fold (0.18 log units) below what was measured, and the stated range covers the measured number.
By their numbers in the PC-12 assay, from the lowest: compounds 1, 3 and 4 (each within the scatter of the next). At a limit, above all of these: compound 2.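

In the PC-12 assay, the loss of the methyl gives a 1.8-fold higher number from compound 3 to compound 4 (0.26 log units; within the scatter), and the comparison with the cyclopentyl compound gives a 1.8-fold higher number from compound 1 to compound 4 (0.26 log units; within the scatter), so the propoxy chain stays with this pair rather than with the cyclobutyl compound. That separation reads as an at least 2.2-fold lower number from compound 2 to compound 4 (0.34 log units; beyond the scatter), and it rests on a limit of the assay for compound 2. In a physicochemical assay for lipophilicity (a higher number here means a more lipophilic compound, a lower number a more polar compound), compound 3 gives 3.36 and compound 4 gives 2.96, so the same change does register: the measured partition coefficient of compound 3, 3.36, and of compound 4, 2.96, a number 0.40 log units lower (beyond the scatter)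

On these data alone, whether a longer chain, or an amine on the chain, would hold this level in the PC-12 assay remains open. Why cyclobutyl alone stands apart also remains open.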